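Dithiocarbamate benzamides: exchanging the amine on the thiocarbonyl

The compounds below may be only part of what the source reports. "The series", "measured", "known", "first", "only" and "open" are said of these compounds alone.

Of the compounds shown here, three on a shared core have been measured: compound 1 `Nc1ccccc1NC(=O)c1ccc(CSC(=S)N2CCN(C3CCCCC3)CC2)cc1`, compound 2 `CCN(Cc1ccncc1)C(=S)SCc1ccc(C(=O)Nc2ccccc2N)cc1` and compound 3 `Nc1ccccc1NC(=O)c1ccc(CSC(=S)N2CCN(c3ccncc3)CC2)cc1`. In a functional assay on MGC-803 cells (Homo sapiens) for antiproliferative activity, read by CCK-8 assay, with a stated time of 72 h, tested at 8 uM (on this read-out higher numbers stand for a stronger effect at the one concentration tested and lower numbers for a weaker effect), compound 1 gives 75.3%, compound 2 gives 85.2% and compound 3 gives 87.1%. Compound 2 stands second highest of the three numbers; its nearest neighbour is compound 3, within the scatter, and its furthest is compound 1, also within the scatter, so no order among the three can be claimed.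

Among the measured compounds shown here, the one step resolved beyond the scatter is a number 11.8 percentage points higher from compound 1 to compound 3 (beyond the scatter), pyridin-4-yl in place of cyclohexyl on an amine nitrogen in a ring.

Compound 4 `CN(C(=S)SCc1ccc(C(=O)Nc2ccccc2N)cc1)c1cccnc1` is not yet measured. Against compound 2 the difference is methyl(pyridin-3-yl)amino in place of ethyl((pyridin-4-yl)methyl)amino on a thiocarbonyl carbon. For the measured compounds named here, the measured step changes a substituent on a ring nitrogen, whereas here the whole amino group on the thiocarbonyl carbon is exchanged, and both the leaving and the entering group carry one six-membered aromatic ring with one hetero atom; no measured pair tracks this exchange. The expectation for compound 4 is therefore no step beyond the scatter, a number 3.2 percentage points lower from compound 2 to compound 4 (within the scatter). Compound 4 is estimated at 82%, expected to fall between 68% and 92%.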

Compound 4, a percentage reported as inhibition, at one concentration (the size of the read-out at that concentration, not a potency): 82.5%
Compound 4: middle estimate off by 0.5 percentage points, on the low side; the range from low to high includes it.
By their numbers in this assay, from the lowest: compounds 1, 4, 2 and 3 (each within the scatter of the next, the first and the last beyond it).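

In this assay, exchanging the whole amino group on the thiocarbonyl carbon, with methyl(pyridin-3-yl)amino in place of ethyl((pyridin-4-yl)methyl)amino, gives a number 2.7 percentage points lower from compound 2 to compound 4 (within the scatter). The earlier compounds shown here showed a resolved step only for a substituent on a ring nitrogen, whereas this pair shows that an exchange at the thiocarbonyl carbon, from 10 heavy atoms to 8 with one six-membered aromatic ring with one hetero atom on both sides, leaves the read-out unresolved. Several features differ at once in this single exchange, and no measurement on these compounds separates them or explains the result.

Open, from the compounds shown here alone, is whether the reading holds when the amino group on the thiocarbonyl carbon carries no aromatic ring, as in dimethylamino or morpholin-4-yl, or carries a carboxylic acid on its pyridine ring. Going by these compounds, the read-out gives the size of the effect at one concentration, so how compound 2 and compound 4 compare in potency also stays open.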